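Swapping thiophene for pyridine on a shared anilinopyrimidine core

A few compounds are considered here, and "the series" means these few. Any claim that something is new, unique, unknown or untested is made for them only; others in the source may bear on it.

Measured compounds:
- compound 1, `COc1ccc(Nc2nccc(-c3ccsc3)n2)cc1`: 15600 nM
- compound 2, `CN(C)c1ccc(Nc2nccc(-c3ccsc3)n2)cc1`: 2100 nM
- compound 3, `CN(C)c1cccc(Nc2nccc(-c3ccncc3)n2)c1`: 3700 nM

In a functional assay for inhibition, with Homo sapiens as the target (a lower number here means a stronger inhibitor, a higher number a weaker inhibitor), compound 1 gives 15600 nM and stands highest of the three numbers; compound 3 sits nearest with 3700 nM and compound 2 furthest with 2100 nM, both gaps beyond the scatter. Among the measured compounds shown here, the one measured step, a 7.4-fold lower number from compound 1 to compound 2 (0.87 log units; beyond the scatter), concerns the methoxy-to-dimethylamino exchange on the aniline and says nothing about the other aryl group.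

Compound 4, `COc1ccc(Nc2nccc(-c3cccnc3)n2)cc1`, differs from compound 1 in exactly that other group:
pyridin-3-yl in place of thiophen-3-yl on an aromatic carbon
For the measured compounds named here, no measured pair isolates this exchange. Going by the values given here, compounds 2 and 3 carry different aryl groups but also differ elsewhere, so the fact that compound 2 gives 2100 nM and compound 3 gives 3700 nM shows only that a pyridyl-bearing compound can sit in the same modest range as a thiophenyl-bearing one. For this assay the step from compound 1 to compound 4 is therefore expected to stay within the usual scatter, in either direction, with a 1.3-fold lower number from compound 1 to compound 4 (0.11 log units; within the scatter) as the estimated change.

Compound 4 is thus estimated at 12000 nM, with a range of 4000 nM to 40000 nM.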

Compound 4, half-maximal inhibitory concentration: 1700 nM
Beside the measured number, compound 4's estimate is 7.1-fold (0.85 log units) above it, and the stated range ends above it.
By their numbers in this assay, from the lowest: compounds 4, 2 and 3 (each within the scatter of the next, the first and the last beyond it); then compound 1.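

The exchange of thiophen-3-yl for pyridin-3-yl on the shared core gives a 9.2-fold lower number from compound 1 to compound 4 (0.96 log units; beyond the scatter) in this assay, so the aryl group at this place, next to the ring nitrogen, affects the number on its own. Among the compounds shown here, until now the only isolated change was at the other end of compound 1, where the methoxy-to-dimethylamino exchange gave a 7.4-fold lower number from compound 1 to compound 2 (0.87 log units; beyond the scatter); compound 1 now has two separate places where a single exchange moves the number beyond the scatter. Nothing available explains the step at the aryl position, and it cannot be assigned to the ring size or to the hetero atom, since a five-membered aromatic ring with sulfur gives way to a six-membered aromatic ring with nitrogen in one move.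

What the compounds shown leave open is whether a plain phenyl or a furan-3-yl at this place would behave like pyridin-3-yl or like thiophen-3-yl, which would help to separate ring size from the identity of the hetero atom. Also open, from the compounds shown here alone, is whether the two exchanges add up when pyridin-3-yl and dimethylamino are carried together on the core of compound 1.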